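Swapping bromo for hydroxy on a quinoline-linked phenyl ring

The source may hold more compounds than are shown below. What is called first, only, known or untested is meant among the compounds shown, and "the series" means these compounds.

Measured so far:
- compound 1, `Cc1ccc2ccc(-c3cccc(C#N)c3)cc2n1`: 7.7 nM
- compound 2, `Cc1ccc2ccc(-c3cc(Br)cc(C#N)c3)cc2n1`: 13 nM

Both compounds were tested in a functional assay on CHO cells for inhibition of metabotropic glutamate receptor 5 (Rattus norvegicus), read by FLIPR and calcium flux; on this read-out lower numbers stand for stronger inhibition and higher numbers for weaker inhibition. Compound 1, `Cc1ccc2ccc(-c3cccc(C#N)c3)cc2n1`, gives 7.7 nM in this assay. Compound 2, `Cc1ccc2ccc(-c3cc(Br)cc(C#N)c3)cc2n1`, gives 13 nM. Of these two numbers, compound 2 shows the higher one, but the step of a 1.7-fold higher number from compound 1 to compound 2 (0.23 log units; within the scatter) is within the usual scatter, so the two compounds cannot be told apart on potency.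

Compound 3, `Cc1ccc2ccc(-c3cc(O)cc(C#N)c3)cc2n1`, has not yet been measured. It differs from compound 2 in one place: hydroxy in place of bromo on an aromatic carbon. Going by the values given here, no measured step compares a hydroxy group with a bromo group, so nothing in the data bears directly on this change. Among the compounds with values here, the only step available, a 1.7-fold higher number from compound 1 to compound 2 (0.23 log units; within the scatter), shows that adding bromo at this position left the number within the scatter. On that thin basis, a step of a 1.5-fold higher number from compound 2 to compound 3 (0.19 log units; within the scatter) is expected from compound 2 to compound 3, most likely no larger than the scatter. For compound 3 the expected value in this assay is 20 nM, with a range from 6 nM to 65 nM.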

Compound 3, half-maximal inhibitory concentration: 360 nM
Beside the measured number, compound 3's estimate is 18-fold (1.26 log units) below it; measured number outside the range, above it.
By their numbers in this assay, from the lowest: compounds 1 and 2 (each within the scatter of the next); then compound 3.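

In this assay the first two compounds made this aromatic carbon, meta to a cyano group, look indifferent to what sits on it, but swapping bromo for hydroxy brings a 28-fold higher number from compound 2 to compound 3 (1.44 log units; beyond the scatter) and swapping hydrogen for hydroxy brings a 47-fold higher number from compound 1 to compound 3 (1.67 log units; beyond the scatter), so the position clearly responds to the choice of group. Bromo and hydroxy have the same heavy-atom count, which therefore cannot separate them, and the visible difference in the counted features is that hydroxy brings a hydrogen-bond donor and a hydrogen-bond acceptor while bromo brings neither, although that difference alone does not establish what drives the drop. No measurement shown here explains why the number rises so sharply with this one swap.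

The compounds shown leave open whether the change is specific to hydroxy or extends to other groups on this carbon, such as a methoxy group, which keeps the oxygen but has no hydroxy hydrogen, or an amine. A fluoro or a chloro group on the same carbon would also show whether other halogens stay as close to hydrogen as bromo does.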